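The compounds below may be only part of what the source reports. "The series", "measured", "known", "first", "only" and "open" are said of these compounds alone.

Measured in a functional assay on the whole organism with Mus musculus as the target, with a stated time of 90 min, at a dose of 25 umol/kg by the oral route; on this read-out higher numbers stand for a stronger effect at the one dose given and lower numbers for a weaker effect: compound 1 `N=C(N)NCCC[C@H](NC(=O)CN(c1nc(Cl)nc2c1ncn2C1CCCCO1)C1CC1)C(=O)OCc1ccccc1` gives 61.6%. Compound 2 `NC(=O)C[C@H](NC(=O)CN(c1nc(Cl)nc2c1ncn2C1CCCCO1)C1CC1)C(=O)OCc1ccccc1` gives 35%. Compound 3 `O=C(CN(c1nc(Cl)nc2c1ncn2C1CCCCO1)C1CC1)N[C@@H](CCC(=O)OCc1ccccc1)C(=O)OCc1ccccc1` gives 25.2%.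

Compound 1 stands highest of the three numbers, and both steps away from it lie beyond the scatter: a number 26.6 percentage points lower from compound 1 to compound 2 (beyond the scatter) and a number 36.4 percentage points lower from compound 1 to compound 3 (beyond the scatter). Compounds 2 and 3 sit within the scatter of each other, a number 9.8 percentage points lower from compound 2 to compound 3 (within the scatter).

Compound 4 `CC(C)[C@H](NC(=O)CN(c1nc(Cl)nc2c1ncn2C1CCCCO1)C1CC1)C(=O)OCc1ccccc1` differs from compound 1 in one place: a group of 3 heavy atoms (3 carbon; no ring) in place of a group of 7 heavy atoms (4 carbon, 3 nitrogen; no ring), on a saturated chain carbon bound to an amide-type nitrogen and a carbonyl carbon. Both measured steps from compound 1 alter the same part of the molecule and both lower the read-out, one modestly and one by a large amount. A drop beyond the scatter is therefore expected here as well, a number 31.6 percentage points lower from compound 1 to compound 4 (beyond the scatter). Compound 4 is estimated at 30%, with a range of 14% to 48%.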

Compound 4, a percentage reported as activity, at one dose (the size of the read-out at that dose, not a potency): 30.1%
The estimate for compound 4 lay 0.1 percentage points below the measured number; the measured number falls inside the stated range.
By their numbers in this assay, from the lowest: compounds 3, 4 and 2 (each within the scatter of the next); then compound 1.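

Isopropyl, with 0 hydrogen-bond donors, gives a number 31.5 percentage points lower from compound 1 to compound 4 (beyond the scatter) and stays level with the other side chains, with a number 4.9 percentage points higher from compound 3 to compound 4 (within the scatter) and a number 4.9 percentage points lower from compound 2 to compound 4 (within the scatter) on this comparison. A small carbon-only group thus reads like carbamoylmethyl and 2-(benzyloxycarbonyl)ethyl, leaving only the group of compound 1, with 3 hydrogen-bond donors, apart from the other three. Nothing available explains this gap.

Still open, on these data alone, is whether a primary amine on a chain of the same length would stand with compound 1 or with the other three. The same question holds for a carboxylic acid.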